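Adding a nitro group to a furan ester

A few compounds are considered here, and "the series" means these few. Any claim that something is new, unique, unknown or untested is made for them only; others in the source may bear on it.

Two esters built on the same core have been measured so far, compound 1 `CC1=CC[C@H]2[C@H](CC[C@]2(C)O)C(C)(C)[C@@H]1CC[C@H]1[C@]2(C)CC[C@H](OC(=O)c3cccc([N+](=O)[O-])c3)C(C)(C)O[C@H]2CC[C@@]1(C)O` and compound 2 `CC1=CC[C@H]2[C@H](CC[C@]2(C)O)C(C)(C)[C@@H]1CC[C@H]1[C@]2(C)CC[C@H](OC(=O)c3ccco3)C(C)(C)O[C@H]2CC[C@@]1(C)O`. In a functional assay on MDA-MB-231 cells (Homo sapiens) for antiproliferative activity, read by MTT assay, with a stated time of 72 h (a higher number here means a weaker inhibitor, a lower number a stronger inhibitor), compound 1 gives 34700 nM and compound 2 gives 14000 nM, which is the lower number of the two and so the stronger result.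

The next compound, compound 3 `CC1=CC[C@H]2[C@H](CC[C@]2(C)O)C(C)(C)[C@@H]1CC[C@H]1[C@]2(C)CC[C@H](OC(=O)c3ccc([N+](=O)[O-])o3)C(C)(C)O[C@H]2CC[C@@]1(C)O`, keeps everything in compound 2 except that furan-2-yl becomes 5-nitrofuran-2-yl: nitro in place of hydrogen on an aromatic carbon. The nitro replaces a hydrogen on an aromatic carbon, next to the ring oxygen.

Within the data shown here, only one measured step bears on this change, the modest 2.5-fold lower number from compound 1 to compound 2 (0.39 log units; beyond the scatter). That step exchanges the 3-nitrophenyl group for furan-2-yl, so the ring changes and the nitro goes in a single move. Among the measured compounds shown here, no measured pair shows the effect of nitro alone. Compound 3 pairs the furan ring of compound 2 with the nitro found in compound 1, so only a small change is expected, a 1.1-fold higher number from compound 2 to compound 3 (0.06 log units; within the scatter). In this assay the estimated value for compound 3 is 16000 nM, with an expected range of 5000 nM to 45000 nM.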

Compound 3, half-maximal inhibitory concentration: 11100 nM
Beside the measured number, compound 3's estimate is 1.4-fold (0.16 log units) above it; the measured number falls inside the stated range.
By their numbers in this assay, from the lowest: compounds 3 and 2 (each within the scatter of the next); then compound 1.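

In this assay, the step that isolates nitro on the furan ring is a 1.3-fold lower number from compound 2 to compound 3 (0.10 log units; within the scatter), which lies within the scatter. On this aromatic carbon next to the ring oxygen, a nitro group in place of hydrogen therefore gives a result that cannot be told apart from that of the parent ester. The second step, a 3.1-fold lower number from compound 1 to compound 3 (0.50 log units; beyond the scatter), is beyond the scatter even though both of its esters carry a nitro group, so among these three compounds the difference goes with exchanging 3-nitrophenyl for a furan ring and not with the presence of nitro itself. No measurement available here offers a reason for either step.

The compounds shown leave open whether a different group at this furan carbon, such as an amine, a carboxylic acid or a longer alkyl chain, would move the number beyond the scatter. An unsubstituted phenyl ester would also be needed to show what the nitro group contributes on the benzene ring of compound 1, which the furan pair cannot reveal.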